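The compounds below may be only part of what the source reports. "The series", "measured", "known", "first", "only" and "open" are said of these compounds alone.

Working notes on the series. The shared core is carried by compound 1 `Cc1ccc(Nc2nc(N)nc(COc3ccc4c(C)cc(=O)oc4c3)n2)cc1Cl`, compound 2 `CCc1cc(=O)oc2c(C)c(OCc3nc(N)nc(Nc4ccc(C)cc4)n3)ccc12`, and compound 3 `Cc1ccc(Nc2nc(N)nc(COc3cc(N4CCCC4=O)cc(C(F)(F)F)c3)n2)cc1Cl`. In an assay on COS-7 cells for agonist activity at Free fatty acid receptor 1 (Homo sapiens), read by scintillation counting and inositol phosphate accumulation, with a stated time of 90 min (a higher number here means that more compound is needed for the effect, a lower number that less compound is needed), compound 1 gives 140 nM. For compound 2 this assay gives "not determined" (no result reported), so no number is available there. In this assay compound 3 gives 3190 nM, the highest of the two numbers recorded; the gap to compound 1 lies beyond the scatter, and nothing beyond the two values themselves is known about that pair.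

The next member is compound 4 `Cc1cc(OCc2nc(N)nc(Nc3ccc(C)c(Cl)c3)n2)cc(N2CCCC2=O)c1`. It differs from compound 3 in one place: methyl in place of trifluoromethyl on an aromatic carbon. Among the compounds with values here, no measured pair in this set shows a change of this kind, so there is no step to lean on.

Given that compound 3 gives 3190 nM, compound 4 is expected to stay in the same region, with a step of a 1.3-fold lower number from compound 3 to compound 4 (0.11 log units; within the scatter) that may not exceed the scatter. The estimate for compound 4 in this assay is 2500 nM, within 600 nM to 10000 nM.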

Compound 4, half-maximal effective concentration: 20 nM
The estimate for compound 4 lay 130-fold (2.10 log units) above the measured number; measured number outside the range, below it.
By their numbers in this assay, from the lowest: compound 4; then compound 1; then compound 3.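

In this assay, within the data shown here, the aromatic carbon meta to a 2-oxopyrrolidin-1-yl group proves highly sensitive to the group it carries: methyl in place of trifluoromethyl gives a 160-fold lower number from compound 3 to compound 4 (2.20 log units; beyond the scatter) and is the only measured step so far. The earlier compounds shown here held no pair differing at this place, so they gave no sign that a change here could matter this much, and the rest of compound 3 is unchanged in compound 4, which ties the whole step to this one place. Nothing at hand bears on why the step is so large.

From the compounds shown here alone, how chlorine, a methoxy group or an ethyl chain would read at this place stays open. Also open, going by these compounds, is whether the same change gives a step of like size on other members.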